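Compound 3 to compound 4: an open chain replaces a ring

A few compounds are considered here, and "the series" means these few. Any claim that something is new, unique, unknown or untested is made for them only; others in the source may bear on it.

In a functional assay on KETR3 cells (Homo sapiens) for inhibition, read by MTT assay, with a stated time of 120 h (a higher number here means a weaker inhibitor, a lower number a stronger inhibitor), compound 3 `CNC(=O)c1cccc(-c2ccc(NC(=O)Nc3ccc(Cl)c(C(F)(F)F)c3)cc2)c1` gives 39300 nM, the higher of the two actual numbers in the series. The nearest number belongs to compound 1 `CC(NC(=O)c1cccc(-c2ccc(NC(=O)Nc3ccc(Cl)c(C(F)(F)F)c3)cc2)c1)c1ccccc1` at 6460 nM. The measured change is a 6.1-fold higher number from compound 1 to compound 3 (0.78 log units; beyond the scatter), but it lies on the amide-type nitrogen and not at the position changed here. Compound 2 `CNC(=O)/C(C)=C/c1ccc(NC(=O)Nc2ccc(Cl)c(C(F)(F)F)c2)cc1` reads > 50000 nM, which is a limit of the assay and not a number.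

Compound 4 `CNC(=O)/C=C(\C)c1ccc(NC(=O)Nc2ccc(Cl)c(C(F)(F)F)c2)cc1` carries 1-methyl-2-(methylcarbamoyl)ethenyl in place of 3-(methylcarbamoyl)phenyl on an aromatic carbon, para to a large group: 1-methyl-2-(methylcarbamoyl)ethenyl in place of 3-(methylcarbamoyl)phenyl on an aromatic carbon. The closest measured precedent is the exchange of 2-(methylcarbamoyl)prop-1-en-1-yl for the same phenyl group, an at least 1.2-fold lower number from compound 2 to compound 3 (0.10 log units; that floor lies within the scatter). That exchange gives no sign of a real difference between the open chain and the ring, so no change beyond the scatter is expected in this assay. The expected step is a 1.1-fold higher number from compound 3 to compound 4 (0.06 log units; within the scatter). A result reported only as a limit would not be surprising. For compound 4 the estimated value is 45000 nM, with an expected range of 20000 nM to 90000 nM.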

Compound 4, half-maximal inhibitory concentration: > 50000 nM
Compound 4: a limit, no number; the forecaster's own chance of this, stated with the estimate: 55%; at least 1.1-fold (0.04 log units) between middle value and limit.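

In this assay compound 4 gives a limit of the assay and not a number, so 1-methyl-2-(methylcarbamoyl)ethenyl joins 2-(methylcarbamoyl)prop-1-en-1-yl at the same limit: the limit of > 50000 nM in this assay, at which 2 of the 4 values shown sit.

Against 3-(methylcarbamoyl)phenyl, the new open chain reads as an at least 1.2-fold higher number from compound 3 to compound 4 (0.10 log units; that floor lies within the scatter), so on these values it cannot be separated from the ring-bearing group at this position. Neither open chain yields a number, and the step between the two open-chain compounds cannot be read.

Among these compounds, how far either open chain really lies from compound 3 stays open, while the one change beyond the scatter remains on the amide-type nitrogen, a 6.1-fold higher number from compound 1 to compound 3 (0.78 log units; beyond the scatter). Whether a carboxylic acid or an amine in place of the methylcarbamoyl group on the open chain would bring a value inside the range of the assay is left unanswered by these compounds.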